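The source may report more compounds than this note shows. Statements on the series, on what has been measured and on what is new or still open speak of the compounds shown alone.

Measured so far: compound 3 `COc1cc(Nc2ncccc2-c2n[nH]c(Nc3ccc4c(c3)OCCO4)n2)cc(OC)c1` gives 83% in a functional assay on A-431 cells (Homo sapiens), tested at 0.1 uM; on this read-out higher numbers stand for more inhibition at the one concentration tested (going by the name of the read-out) and lower numbers for less inhibition; compound 1 `COc1cc(Nc2ncccc2-c2n[nH]c(Nc3ccc(N(C)C)cc3)n2)cc(OC)c1` gives "not determined" (no result reported) and compound 2 `COc1cc(Nc2ncccc2-c2n[nH]c(Nc3ccc(C#N)cc3)n2)cc(OC)c1` gives "not determined" (no result reported) in this assay, that is, no reported number for either.

Compound 3 therefore stands alone on the numbers shown: its value is the only one available, and no step between measured compounds can be drawn from the set. Compound 4 `COc1cc(OC)cc(Oc2ncccc2-c2n[nH]c(Nc3ccc4c(c3)OCCO4)n2)c1` differs from compound 3 in a single place: 3,5-dimethoxyphenoxy in place of (3,5-dimethoxyphenyl)amino on an aromatic carbon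

Among the compounds with values here, with no comparable step measured, the size of the step in this assay remains open. Compound 3 sits high on this read-out, which leaves more room downward than upward. A decrease of moderate size is expected for compound 4, that is a number 28 percentage points lower from compound 3 to compound 4 (beyond the scatter), so that compound 4 is estimated at 55%, with a range from 20% to 85%.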

Compound 4, a percentage reported as inhibition, at one concentration (the size of the read-out at that concentration, not a potency): 89%
The estimate for compound 4 lay 34 percentage points below the measured number; the whole stated range lies below it.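

In this assay, 3,5-dimethoxyphenoxy in place of (3,5-dimethoxyphenyl)amino on the aromatic carbon next to the ring nitrogen gives a number 6 percentage points higher from compound 3 to compound 4 (within the scatter). At this place, the oxygen-linked group therefore holds the read-out as well as the amino-linked group does, at the one concentration tested. Nothing at hand bears on the reason for this result. Going by these compounds, whether a methylene or thioether link at this place would also hold the read-out remains open. With a single high reading for each compound, any difference in potency between compound 3 and compound 4 also remains unresolved.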